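This account rests on a few compounds, and the source may have more. Where it says the series, first, only, none or still open, it means among the compounds named here.

In an ADME assay on microsomes from liver (Homo sapiens) for metabolic stability, with a stated time of 60 min, tested at 1 mg/mL (on this read-out higher numbers stand for fast clearance and lower numbers for slow clearance), compound 1 (`COc1nc2ccc(Br)cc2cc1[C@@H](c1cc(C)c(C)s1)[C@@](O)(CCN(C)C)c1cccc(F)c1`) gives 12 mL.min-1.g-1 and compound 2 (`COc1cc([C@H](c2cc3cc(Br)ccc3nc2OC)[C@@](O)(CCN(C)C)c2cccc(F)c2)cnc1OC`) gives 36 mL.min-1.g-1 as the higher of the two numbers. Compound 3 (`CCSc1ccc([C@H](c2cc3cc(Br)ccc3nc2OC)[C@@](O)(CCN(C)C)c2cccc(F)c2)cn1`) has not yet been measured. It differs from compound 2 in one place (6-(ethylsulfanyl)pyridin-3-yl in place of 5,6-dimethoxypyridin-3-yl on a saturated chain carbon bound to an aromatic carbon and a saturated chain carbon), on a saturated chain carbon bound to an aromatic carbon and a saturated chain carbon. For the measured compounds named here, only one measured step bears on this change, the modest one at that same place (a 3.0-fold higher number from compound 1 to compound 2 (0.48 log units; beyond the scatter)). That step exchanged a different pair of groups, so it indicates a possible size but no direction. Here, both the leaving and the entering group hold one six-membered aromatic ring with 1 hetero atom. What is expected is a step (a 1.1-fold higher number from compound 2 to compound 3 (0.05 log units; within the scatter)) that stays within the scatter. Compound 3 is accordingly estimated at 40 mL.min-1.g-1 and expected to fall between 18 mL.min-1.g-1 and 85 mL.min-1.g-1 in this assay.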

Compound 3, intrinsic clearance in microsomes: 11 mL.min-1.g-1
Compound 3: the middle estimate sits 3.6-fold (0.56 log units) above what was measured, and the stated range ends above it.
By their numbers in this assay, from the lowest: compounds 3 and 1 (each within the scatter of the next); then compound 2.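

In this assay, 6-(ethylsulfanyl)pyridin-3-yl in place of 5,6-dimethoxypyridin-3-yl on this saturated chain carbon gives a step beyond the scatter (a 3.3-fold lower number from compound 2 to compound 3 (0.51 log units; beyond the scatter)), so two groups that each hold one six-membered aromatic ring with 1 hetero atom do not read alike at this place. For the compounds shown here, exchanging 4,5-dimethylthiophen-2-yl for 6-(ethylsulfanyl)pyridin-3-yl stays within the scatter (a 1.1-fold lower number from compound 1 to compound 3 (0.04 log units; within the scatter)), which leaves 5,6-dimethoxypyridin-3-yl as the one group of the three that stands apart. No measurement offered here accounts for these differences.

Compound 2 and compound 3 differ at once in the sulfur, the ethyl chain and the number of methoxy groups, and the compounds shown do not separate these. From the compounds shown here alone, how a 6-methoxypyridin-3-yl or a 6-(methylsulfanyl)pyridin-3-yl group would read at this place stays open.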